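Aryl swap on the ring nitrogen: outlook for compound 4

The source may hold more compounds than are shown below. What is called first, only, known or untested is meant among the compounds shown, and "the series" means these compounds.

The series shares the core seen in compound 1 `COc1ccccc1N1C(=O)CSC1C(=O)NCCCCc1ccccc1`, varied at the group on the amide-type nitrogen in the ring and at the ring substituent. In a functional assay on U2OS cells (Homo sapiens) for inhibition, read by CCK-8 assay, with a stated time of 72 h, tested at 1 uM (a lower number here means less inhibition, a higher number more inhibition at the concentration tested (going by the name of the read-out)), compound 1 gives 6%. Compound 2 `COc1ccc(F)cc1N1C(=O)CSC1c1cccc(C(=O)NCCCCc2ccccc2)c1` gives 32% in this assay, the second highest of the three numbers, with compound 1 below it and compound 3 `O=C(NCCCCc1ccccc1)c1cccc(C2SCC(=O)N2c2ccccc2)c1` above it. Compound 3 gives 68% in this assay. Among the compounds with values here, the one measured step that bears on the present change, a number 36 percentage points higher from compound 2 to compound 3 (beyond the scatter), is large. Compound 4 `Cc1cccc(N2C(=O)CSC2c2cccc(C(=O)NCCCCc3ccccc3)c2)c1` differs from compound 2 by 3-methylphenyl in place of 5-fluoro-2-methoxyphenyl on an amide-type nitrogen in a ring. For compound 4 a step in the same direction is expected, estimated as a number 23 percentage points higher from compound 2 to compound 4 (beyond the scatter). Compound 4 is expected to give 55% in this assay, in the range 30% to 75%.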

Compound 4, a percentage reported as inhibition, at one concentration (the size of the read-out at that concentration, not a potency): 39%
Compound 4: middle estimate off by 16 percentage points, on the high side; low and high end bracket the measured number.
By their numbers in this assay, from the lowest: compound 1; then compounds 2 and 4 (each within the scatter of the next); then compound 3.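

Going to 3-methylphenyl on the amide-type nitrogen gives a number 7 percentage points higher from compound 2 to compound 4 (within the scatter) in this assay, so the gain seen with unsubstituted phenyl does not carry over to this aryl group. Methyl in place of hydrogen on an aromatic carbon gives a number 29 percentage points lower from compound 3 to compound 4 (beyond the scatter) and is the only difference between these two compounds, so one methyl on this ring is enough to shift the number beyond the scatter. Nothing at hand explains this shift.

From the compounds shown here alone, whether an amine or a carboxylic acid in place of that methyl would keep the number of compound 3 remains open. So does whether a chlorine atom would behave like the methyl.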